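The source may report more compounds than this note shows. Statements on the series, on what has been measured and on what is new or still open speak of the compounds shown alone.

In an ADME assay on cells (Rhabdomyosarcoma cell, Homo sapiens) for cytotoxicity, read by MTT assay, with a stated time of 72 h (a higher number here means that more compound is tolerated, a lower number that less compound is tolerated), compound 3 `C(=N/c1sc2c(c1-c1nc3ccccc3s1)CCCC2)\c1ccccc1` gives 71.1 ug/mL and thus lies within the scatter of compound 2 `Oc1ccccc1/C=N/c1sc2c(c1-c1nc3ccccc3s1)CCC2` at 100 ug/mL and of compound 1 `Clc1ccccc1/C=N/c1sc2c(c1-c1nc3ccccc3s1)CCC2` at 123 ug/mL in this small set. The next compound, compound 4 `FC(F)(F)c1ccc(/C=N/c2sc3c(c2-c2nc4ccccc4s2)CCCC3)cc1`, differs from compound 3 by trifluoromethyl in place of hydrogen on an aromatic carbon and by nothing else, a phenyl becoming a 4-(trifluoromethyl)phenyl. Going by the values given here, only one measured step bears on this change, and only loosely: a 1.2-fold lower number from compound 1 to compound 2 (0.09 log units; within the scatter) is also an exchange on an aromatic carbon, and it did not leave the scatter. Among the compounds with values here, no measured compound carries a trifluoromethyl group, so the size of this particular exchange has not been observed directly. Within the data shown here, the three values so far also sit close together, which gives no ground for expecting a large move in either direction. The expected change is a 1.1-fold higher number from compound 3 to compound 4 (0.02 log units; within the scatter) and is estimated to remain within the scatter. For compound 4 the estimate in this assay is 75 ug/mL as a central value, with an expected range from 35 ug/mL up to 150 ug/mL for repeated measurements.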

Compound 4, half-maximal cytotoxic concentration: 250 ug/mL
For compound 4 the middle estimate is 3.3-fold (0.52 log units) below the measured one; measured number above the stated range.
By their numbers in this assay, from the lowest: compounds 3, 2 and 1 (each within the scatter of the next); then compound 4.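

In this assay, going by these compounds alone, the exchange on an aromatic carbon para to a large group gives a 3.5-fold higher number from compound 3 to compound 4 (0.55 log units; beyond the scatter), the first step in this set to leave the scatter, and the change is toward more compound being tolerated. Within the data shown here, this shows that a single replacement of hydrogen by trifluoromethyl on the phenyl of compound 3 is enough to shift this read-out, which the one earlier step, staying within the scatter, had given no sign of. Nothing available here accounts for the rise.

Going by these compounds, it remains open whether the shift belongs to trifluoromethyl itself or would also follow from another group at this place, such as methoxy, an amine or a carboxylic acid. Also open, on these data alone, is whether the same exchange would have a similar effect on the core of compound 1.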